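Carbamate Replaces Ester on the Oxazolidinone Side Chain

The source may report more compounds than this note shows. Statements on the series, on what has been measured and on what is new or still open speak of the compounds shown alone.

Of the compounds shown here, three sharing one core have been measured in a physicochemical assay for solubility, read by HPLC, with a stated time of 24 h; on this read-out higher numbers stand for higher solubility and lower numbers for lower solubility. Compound 1 `O=C1CCC(=O)N1C[C@H]1CN(c2ccc(-n3cc(-c4ccccn4)cn3)c(F)c2)C(=O)O1` gives 45300 nM. Compound 2 `O=C1CNC(=O)N1C[C@H]1CN(c2ccc(-n3cc(-c4ccccn4)cn3)c(F)c2)C(=O)O1` gives 1630000 nM. Compound 3 `CC(=O)OC[C@H]1CN(c2ccc(-n3cc(-c4ccccn4)cn3)c(F)c2)C(=O)O1` gives 373000 nM, which places it second highest of the three, with compound 2 above it and compound 1 below. The step of a 36-fold higher number from compound 1 to compound 2 (1.56 log units; beyond the scatter) was large; the steps of an 8.2-fold higher number from compound 1 to compound 3 (0.92 log units; beyond the scatter) and a 4.4-fold lower number from compound 2 to compound 3 (0.64 log units; beyond the scatter) were modest.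

Compound 4 `COC(=O)NC[C@H]1CN(c2ccc(-n3cc(-c4ccccn4)cn3)c(F)c2)C(=O)O1` has not yet been measured. It differs from compound 3 in one place: (methoxycarbonyl)amino in place of acetoxy on a saturated chain carbon bound to a saturated ring carbon. Among the measured compounds shown here, no measured pair swaps acetoxy for (methoxycarbonyl)amino, so the nearest guide is indirect: the only measured group carrying one hydrogen-bond donor, in compound 2, sits highest, and the entering group here also carries one donor. On that basis a modest upward step a 1.6-fold higher number from compound 3 to compound 4 (0.21 log units; within the scatter) is expected in this assay, though it could fall within the scatter. Compound 4 is estimated at 600000 nM, with a likely range from 180000 nM to 1800000 nM.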

Compound 4, solubility: 34100 nM
Estimate against measurement, compound 4: 18-fold (1.25 log units) above, and the stated range ends above it.
By their numbers in this assay, from the lowest: compounds 4 and 1 (each within the scatter of the next); then compound 3; then compound 2.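

In this assay, among the compounds shown here, the earlier compounds hinted that a hydrogen-bond donor on this saturated chain carbon might go with a higher number, but compound 4 breaks that reading: replacing acetoxy with (methoxycarbonyl)amino adds a donor and still gives an 11-fold lower number from compound 3 to compound 4 (1.04 log units; beyond the scatter) in this series. Compound 4 also shares that feature with compound 2, yet the ring-to-chain change gives a 48-fold lower number from compound 2 to compound 4 (1.68 log units; beyond the scatter) here, while exchanging 2,5-dioxopyrrolidin-1-yl for the same open chain gives a 1.3-fold lower number from compound 1 to compound 4 (0.12 log units; within the scatter) at this position. Having a donor therefore does not sort these four compounds, and no measurement shown offers an explanation for the differences.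

The compounds shown leave open how an amine or a carboxylic acid at this position would compare. They also leave open whether a longer chain, such as (ethoxycarbonyl)amino, would stay close to compound 4.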